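The source may report more compounds than this note shows. Statements on the series, on what has been measured and on what is new or still open speak of the compounds shown alone.

Working notes on the series. Compound 1 `CC(C)(C)Nc1nc(N)c(C(=O)N=C(N)N)nc1Cl` carries no result in an assay for inhibition of acid-sensing ion channel 3 (Homo sapiens), read by patch clamp, tested at 1 uM; a lower number here means less inhibition, a higher number more inhibition at the concentration tested (going by the name of the read-out): for compound 1 the entry reads "not determined" (no result reported). Among the compounds with values here, compound 2 `NC(N)=NC(=O)c1nc(Cl)c(Nc2ccccc2)nc1N` is the only entry with a number: in this assay compound 2 gives 44%, so it stands as the sole reference point for the series. Compound 3 `NC(N)=NC(=O)c1nc(Cl)c(Nc2ccc(C(F)(F)F)cc2)nc1N` differs from compound 2 by trifluoromethyl in place of hydrogen on an aromatic carbon. Within the data shown here, no step between measured compounds is available to calibrate this change, so the expected step from compound 2 to compound 3 in this assay is a number 6 percentage points higher from compound 2 to compound 3 (within the scatter), a small rise at most and possibly nothing beyond the scatter. Compound 3 is estimated at 50%, within 30% to 70%.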

Compound 3, a percentage reported as inhibition, at one concentration (the size of the read-out at that concentration, not a potency): 50%
For compound 3 middle estimate and measured number coincide at the digits printed, within the range that was stated.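

In this assay the series now has its first step: trifluoromethyl in place of hydrogen, para to a large group, gives a number 6 percentage points higher from compound 2 to compound 3 (within the scatter) and so does not separate compound 3 from compound 2. This position therefore accepts a group of 4 heavy atoms with the read-out held within the scatter, a single step that sets no trend. Nothing available bears on the reason for this result. Going by these compounds, whether an amine or a carboxylic acid at this carbon would move the read-out beyond the scatter remains open. Also open, on these data alone, is whether trifluoromethyl on another carbon of the aromatic ring would behave alike.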